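This account rests on a few compounds, and the source may have more. Where it says the series, first, only, none or still open, it means among the compounds named here.

Values in a functional assay on V79 cells (Cricetulus griseus) for cytotoxicity, read by colony formation; on this read-out lower numbers stand for stronger inhibition and higher numbers for weaker inhibition:
- compound 1 `COc1c(N2CCC(C)(CN)C2)c(F)cc2c(=O)c(C(=O)O)cn(C3CC3)c12`: 38 ug/mL
- compound 2 `O=C(O)c1cn(C2CC2)c2c(Cl)c(N3CCNCC3)c(F)cc2c1=O`: 43 ug/mL

Compound 2 stands at 43 ug/mL, within the scatter of compound 1 at 38 ug/mL, so the two measured values do not separate.

Compound 3 `COc1c(N2CCNCC2)c(F)cc2c(=O)c(C(=O)O)cn(C3CC3)c12` follows from compound 2 by a single exchange, methoxy in place of chloro on an aromatic carbon, ortho to a piperazin-1-yl group. Among the measured compounds shown here, no measured pair isolates this exchange. Compound 1 carries methoxy with a different amine group and gives 38 ug/mL, so no step beyond the scatter is expected in this assay, in either direction. The estimated 1.0-fold higher number from compound 2 to compound 3 (0.02 log units; within the scatter) is expected to stay within the scatter. For compound 3 the expected value is 45 ug/mL, with an estimated range of 20 ug/mL to 100 ug/mL.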

Compound 3, half-maximal inhibitory concentration: 82 ug/mL
For compound 3 the middle estimate is 1.8-fold (0.26 log units) below the measured one; the measured number falls inside the stated range.
By their numbers in this assay, from the lowest: compounds 1, 2 and 3 (each within the scatter of the next, the first and the last beyond it).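

In this assay, methoxy in place of chloro on the aromatic carbon ortho to a piperazin-1-yl group gives a 1.9-fold higher number from compound 2 to compound 3 (0.28 log units; within the scatter), so this exchange is now read directly at this position and does not separate from the scatter. With methoxy kept in place, piperazin-1-yl in place of 3-(aminomethyl)-3-methylpyrrolidin-1-yl gives a 2.2-fold higher number from compound 1 to compound 3 (0.33 log units; beyond the scatter), a modest step and the only one of the two that clears the scatter. No measurement on hand gives a cause for either step.

From the compounds shown here alone, whether the amine step holds with chloro at this carbon remains open, as the pair compared here carries methoxy. Also open, going by these compounds, is how a longer ether such as ethoxy, or a nitrile, at this aromatic carbon reads in this assay, alongside piperazin-1-yl.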